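Swapping thiophen-2-yl for thiophen-3-yl on a shared core

A few compounds are considered here, and "the series" means these few. Any claim that something is new, unique, unknown or untested is made for them only; others in the source may bear on it.

- compound 1 `OC[C@H]1O[C@@H](n2cc(F)c3c(-c4ccsc4)ncnc32)[C@H](O)[C@@H]1O` gives 620 nM
- compound 2 `OC[C@H]1O[C@@H](n2cc(Cl)c3c(-c4cccs4)ncnc32)[C@H](O)[C@@H]1O` gives 4970 nM

In an ADME assay on BJ cells (Homo sapiens) for cytotoxicity, read by MTT assay, with a stated time of 72 h (a higher number here means that more compound is tolerated, a lower number that less compound is tolerated), compound 2 stands highest of the two measured compounds, with 4970 nM against 620 nM for compound 1, a gap beyond the scatter. Compound 3 `OC[C@H]1O[C@@H](n2cc(Cl)c3c(-c4ccsc4)ncnc32)[C@H](O)[C@@H]1O` has the same atoms as compound 2, joined differently: thiophen-3-yl in place of thiophen-2-yl on an aromatic carbon in the shared core. Among the measured compounds shown here, no measured pair shows this change alone. Compound 1 also carries thiophen-3-yl and gives 620 nM in this assay, so a drop beyond the scatter is expected, with an estimated 3.1-fold lower number from compound 2 to compound 3 (0.49 log units; beyond the scatter) as the step. The estimate for compound 3 is 1600 nM (range 500 nM to 5000 nM).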

Compound 3, half-maximal cytotoxic concentration: 1720 nM
The estimate for compound 3 lay 1.1-fold (0.03 log units) below the measured number; the measured number falls inside the stated range.
By their numbers in this assay, from the lowest: compound 1; then compound 3; then compound 2.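

In this assay thiophen-3-yl in place of thiophen-2-yl gives a 2.9-fold lower number from compound 2 to compound 3 (0.46 log units; beyond the scatter) with the chloro group held fixed, so the attachment point of the thiophene alone changes the result at this position. Chloro in place of fluoro gives a 2.8-fold higher number from compound 1 to compound 3 (0.44 log units; beyond the scatter) with thiophen-3-yl held fixed. The wide gap between compound 1 and compound 2 therefore splits into two single-change steps of similar size. From the compounds shown here alone, how an amine or a phenyl ring would fare at this position remains open, as does whether thiophen-2-yl has the same effect alongside fluoro. Nothing available explains why either step occurs.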